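This account rests on a few compounds, and the source may have more. Where it says the series, first, only, none or still open, it means among the compounds named here.

Measured compounds:
- compound 1 `O=C(N/N=C/c1cccc(O)c1)c1cnccn1` gives 88%
- compound 2 `O=C(N/N=C/c1ccc(O)cc1)c1cnccn1` gives 80%
- compound 3 `N#Cc1cccc(/C=N/NC(=O)c2cnccn2)c1` gives 100%

All three numbers come from an ADME assay on J774 cells (Mus musculus) for cytotoxicity, read by MTT assay, with a stated time of 48 h, tested at 150 ug/mL; on this read-out lower numbers stand for a stronger effect and higher numbers for a weaker effect at the one concentration tested. Compound 3 stands at 100%, the top of the set. For the measured compounds named here, the one counted step among the measured compounds is a number 12 percentage points higher from compound 1 to compound 3 (beyond the scatter), which goes with this change: cyano in place of hydroxy on an aromatic carbon. Compound 1 and compound 2 share the same atoms joined differently; the difference between the two cores is not broken down here, and their values sit within the scatter of one another, so no order between them is claimed.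

The unmeasured compound 4 `N#Cc1ccc(/C=N/NC(=O)c2cnccn2)cc1` relates to compound 2 as compound 3 relates to compound 1. The change is cyano in place of hydroxy on an aromatic carbon. Going by the values given here, it is the same kind of change as the one from compound 1 to compound 3, not the same: there the entering group sits meta to a large group, here it sits para to a large group.

Among the compounds with values here, since the step from compound 1 to compound 3 in this assay is a number 12 percentage points higher from compound 1 to compound 3 (beyond the scatter), a step of similar size and direction is expected from compound 2, namely a number 12 percentage points higher from compound 2 to compound 4 (beyond the scatter), with the caveat that only one such step is known and the place differs. Compound 4 is therefore estimated at 92% in this assay, expected to lie between 80% and 100%.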

Compound 4, a percentage reported as activity, at one concentration (the size of the read-out at that concentration, not a potency): 100%
Estimate against measurement, compound 4: 8 percentage points below; low and high end bracket the measured number.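

In this assay, cyano in place of hydroxy on the core of compound 2 gives a number 20 percentage points higher from compound 2 to compound 4 (beyond the scatter), and the size of this step cannot be told apart from that of the earlier one: the same change on two cores in this assay, a number 12 percentage points higher (beyond the scatter) from compound 1 to compound 3 and a number 20 percentage points higher (beyond the scatter) from compound 2 to compound 4, 8 percentage points apart, within the scatter of two such steps.

Across these two pairs, the change carries from one core to the other in the same direction, towards a higher number and so a weaker effect at the one concentration tested, with the cyano para to a large group in compound 4. It does not show that the step holds beyond these two pairs or explain why it occurs, and the two cyano compounds, compound 3 at 100% and compound 4 at 100%, give the same number, which says nothing about a wider trend.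

As far as these compounds go, it remains open whether an amine, a carboxylic acid or a methoxy group in place of the hydroxy would move the number in the same direction. Also open, from the compounds shown here alone, is whether the step from hydroxy to cyano would carry over to a core that differs elsewhere from the two shared here, for example one bearing a longer chain.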